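Cyclising the Basic Amine of a Weakly Active Anilide

A few compounds are considered here, and "the series" means these few. Any claim that something is new, unique, unknown or untested is made for them only; others in the source may bear on it.

Compound 1 `COc1ccc(-c2cc3ccc(OC)cc3nc2Nc2ccc(NC(=O)CN3CCN(C)CC3)cc2)cc1`: 2800 nM
Compound 2 `COc1ccc(-c2cc3cc(OC)ccc3nc2Nc2ccc(NC(=O)CN(C)C)cc2)cc1`: 39500 nM
Compound 3 `CCN(CC)CC(=O)Nc1ccc(Nc2nc3ccc(OC)cc3cc2-c2ccc(OC)cc2)cc1`: > 50000 nM

In a functional assay on MCF7 cells (Homo sapiens) for antiproliferative activity, read by MTT assay, with a stated time of 48 h (a higher number here means a weaker inhibitor, a lower number a stronger inhibitor), compound 1 gives 2800 nM and compound 2 gives 39500 nM. For compound 3 the assay returns only a limit, > 50000 nM, so compound 3 sits at the limit of > 50000 nM in this assay, at which 1 of the 3 values shown sits, rather than at a number. Within the data shown here, the one measured step that touches this part of the molecule, an at least 1.2-fold higher number from compound 2 to compound 3 (0.10 log units; that floor lies within the scatter), stays within the scatter. Compound 4 `COc1ccc(-c2cc3cc(OC)ccc3nc2Nc2ccc(NC(=O)CN3CCCC3)cc2)cc1` differs from compound 3 by pyrrolidin-1-yl in place of diethylamino on a saturated chain carbon bound to a carbonyl carbon. Among the measured compounds shown here, no measured step covers this exact exchange, and the nearest one, an at least 1.2-fold higher number from compound 2 to compound 3 (0.10 log units; that floor lies within the scatter), gives no direction beyond the scatter, so compound 4 is expected to stay close to where compound 3 stands, with an expected step of an at least 1.2-fold lower number from compound 3 to compound 4 (0.09 log units; that floor lies within the scatter). Compound 4 is therefore estimated at 40000 nM, between 12000 nM and 120000 nM.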

Compound 4, half-maximal inhibitory concentration: 7290 nM
Compound 4: the middle estimate sits 5.5-fold (0.74 log units) above what was measured, outside the stated range (below it).
By their numbers in this assay, from the lowest: compound 1; then compound 4; then compound 2. At a limit, above all of these: compound 3.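

With pyrrolidin-1-yl on the saturated chain carbon bound to a carbonyl carbon, the series shows an at least 6.8-fold lower number from compound 3 to compound 4 (0.83 log units; beyond the scatter) and a 5.4-fold lower number from compound 2 to compound 4 (0.73 log units; beyond the scatter) against the two open-chain amines. Among these compounds, this is the first exchange at this position to move beyond the scatter, whereas diethylamino for dimethylamino gave no direction. The first of these steps has only a floor, set by a limit for compound 3: the limit of > 50000 nM in this assay, at which 1 of the 4 values shown sits.

As far as these compounds go, whether a piperidine or morpholine ring at this carbon would do the same remains open. So does whether a longer chain leading to the pyrrolidine would keep the lower number.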